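Working notes: one numbered value among three in the series

The compounds below may be only part of what the source reports. "The series", "measured", "known", "first", "only" and "open" are said of these compounds alone.

Compound 1 `Oc1ccc(-c2nc3cc(C(F)(F)F)ccc3[nH]2)cc1` was tested in an ADME assay on BHK cells (Mesocricetus auratus) for cytotoxicity, read by MTT assay, with a stated time of 96 h; on this read-out lower numbers stand for higher toxicity in this test and higher numbers for lower toxicity in this test. In this assay compound 1 reaches only the limit of > 100000 nM. Compound 2 `COc1ccc(-c2nc3cc(C(F)(F)F)ccc3[nH]2)c(OC)c1` in this assay likewise reaches only the limit of > 100000 nM. Among the compounds with values here, compound 3 `CCC(=O)Nc1ccc(-c2nc3cc(C(F)(F)F)ccc3[nH]2)cc1` is the single member with a read number, giving 100000 nM in this assay. It therefore stands as the only numbered point in the series. Within the data shown here, the one measured step, a number no higher from compound 1 to compound 3 (the limit leaves the size open), is propanoylamino in place of hydroxy on an aromatic carbon, and its size cannot be read because of the limit of > 100000 nM in this assay, at which 2 of the 3 values shown sit.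

Compound 4 `COc1ccc(-c2nc3cc(C(F)(F)F)ccc3[nH]2)cc1` differs from compound 3 as follows: methoxy in place of propanoylamino on an aromatic carbon. Among the measured compounds shown here, no measured step touches this exact change; the one step that exists, from hydroxy to propanoylamino, changes the same position but leaves its size open. Compound 2, which also carries methoxy, sits at a limit. The step from compound 3 to compound 4 is therefore expected to be no change at the digits printed from compound 3 to compound 4 (within the scatter), not beyond the scatter. Compound 4 is estimated at 100000 nM, within 50000 nM to 200000 nM, with a real chance that this assay again returns only a limit.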

Compound 4, half-maximal cytotoxic concentration: > 100000 nM
Compound 4 was reported as a limit (the forecaster's own chance of this, stated with the estimate: 60%); the middle value sits exactly at the limit.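

At this position, para to a large group, methoxy now joins hydroxy in giving only a limit in this assay, and the comparison with propanoylamino reads as a number no lower from compound 3 to compound 4 (the limit leaves the size open), with no size attached. The steps linking compound 4 to compound 1 and to compound 2 cannot be read because both ends of each step are limits: the limit of > 100000 nM in this assay, at which 3 of the 4 values shown sit. Compound 3 therefore remains the only compound with a read number, and no change shown at this position gives a step of readable size.

As far as these compounds go, it remains open whether any group at this position gives a clearly lower number than those seen so far. An amine, a carboxylic acid or a longer chain in place of propanoylamino could show whether this position affects the read-out at all.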